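Chlorophenyl against fluorophenyl: antiproliferative notes

A few compounds are considered here, and "the series" means these few. Any claim that something is new, unique, unknown or untested is made for them only; others in the source may bear on it.

- compound 1 `N=C(N)N/N=C(/C=C/c1ccc(Cl)cc1)c1ccccc1` gives 700 nM in a functional assay on MCF7 cells (Homo sapiens) for antiproliferative activity, read by MTT assay, with a stated time of 48 h; a higher number here means a weaker inhibitor, a lower number a stronger inhibitor
- compound 2 `N=C(N)N/N=C(/C=C/c1cccc(F)c1)c1ccccc1` gives 16000 nM in this assay

Compound 2 holds the higher of the two numbers and is the weaker inhibitor of the pair. Compound 3 `N=C(N)N/N=C(/C=C/c1ccccc1Cl)c1ccccc1` carries 2-chlorophenyl in place of 3-fluorophenyl on a double-bonded chain carbon bound to a double-bonded chain carbon is the whole change. For the measured compounds named here, the one measured step bearing on it is a 23-fold higher number from compound 1 to compound 2 (1.36 log units; beyond the scatter), a large step at the same place. Going by the values given here, no 2-chlorophenyl compound has been measured, so a sizeable fall in this assay is expected, probably short of the full distance to compound 1. The expected move is a 5.3-fold lower number from compound 2 to compound 3 (0.73 log units; beyond the scatter) in this series. Compound 3 is estimated at 3000 nM with an expected range from 700 nM to 13000 nM in this assay.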

Compound 3, half-maximal inhibitory concentration: 4200 nM
Beside the measured number, compound 3's estimate is 1.4-fold (0.15 log units) below it; the measured number falls inside the stated range.
By their numbers in this assay, from the lowest: compound 1; then compound 3; then compound 2.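

With chlorine kept and only its place on the phenyl ring changed, 2-chlorophenyl still gives a 6.0-fold higher number from compound 1 to compound 3 (0.78 log units; beyond the scatter) in this assay, so the placement of the halogen alone moves the number. The same group gives a 3.8-fold lower number from compound 2 to compound 3 (0.58 log units; beyond the scatter), recovering only part of the gap at this position. No measurement explains either difference.

Compound 2 and compound 3 differ in both halogen and its placement, so these two effects remain unseparated; 3-chlorophenyl or 4-fluorophenyl could separate them. Going by these compounds, whether a phenyl ring carrying an amine or a carboxylic acid is tolerated here also remains open.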